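Swapping Formyl for Methyl on a Shared Core

The source may hold more compounds than are shown below. What is called first, only, known or untested is meant among the compounds shown, and "the series" means these compounds.

Compounds measured so far:
Compound 1, `Fc1ccc(C2(c3ccc(F)cc3)CNC(c3cccc(C(F)(F)F)c3)=N2)cc1`: 6.2 nM
Compound 2, `O=Cc1cccc(C2=NC(c3ccc(F)cc3)(c3ccc(F)cc3)CN2)c1`: 8.7 nM

Both compounds were tested in an assay on LM cells for displacement of a labelled ligand from Neuropeptide Y receptor type 5 (Homo sapiens); a lower number here means a stronger inhibitor, a higher number a weaker inhibitor. Going by the values given here, on these two numbers compound 2 stands highest, with compound 1 as its only neighbour, and the step of a 1.4-fold higher number from compound 1 to compound 2 (0.15 log units; within the scatter) shows that the two results cannot be told apart.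

Compound 3, `Cc1cccc(C2=NC(c3ccc(F)cc3)(c3ccc(F)cc3)CN2)c1`, is the next member of the series. Its difference from compound 2 is methyl in place of formyl on an aromatic carbon; cut one bond further out, the change reads 3-formylphenyl to 3-methylphenyl.

Among the compounds with values here, only one measured step touches this part of the shared core: the exchange of trifluoromethyl for formyl at the same aromatic carbon, a 1.4-fold higher number from compound 1 to compound 2 (0.15 log units; within the scatter), which stayed within the scatter. Two groups of quite different kind therefore gave indistinguishable numbers at this position. The move to methyl is expected to behave the same way, with a step of a 1.1-fold lower number from compound 2 to compound 3 (0.04 log units; within the scatter) that stays within the scatter. Compound 3 is therefore estimated at 8 nM in this assay, with a range from 3 nM to 25 nM.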

Compound 3, half-maximal inhibitory concentration: 30 nM
For compound 3 the middle estimate is 3.8-fold (0.57 log units) below the measured one; measured number outside the range, above it.
By their numbers in this assay, from the lowest: compounds 1 and 2 (each within the scatter of the next); then compound 3.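

In this assay this position turns out not to be indifferent to the group it carries: the change to methyl is a real one, both from formyl (a 3.4-fold higher number from compound 2 to compound 3 (0.54 log units; beyond the scatter)) and from trifluoromethyl (a 4.8-fold higher number from compound 1 to compound 3 (0.68 log units; beyond the scatter)), and both steps are modest but lie beyond the scatter. The earlier agreement between trifluoromethyl and formyl therefore holds for that pair of groups only and does not extend to every group at this aromatic carbon, since compound 3, with methyl, is the weakest of the three compounds. No outside measurement is available to explain why methyl gives the higher number, so the result stands here as an observation only.

The three groups leave open how an amine, a carboxylic acid or a hydroxymethyl group would read on this aromatic carbon, and whether a chlorine atom or a longer chain such as ethyl would sit with methyl or with the other two. On these data alone, it also remains open whether the step from formyl to methyl would be the same size on a different core.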